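Mouse microsomal stability: benzimidazole amide from compound 1

The source may hold more compounds than are shown below. What is called first, only, known or untested is meant among the compounds shown, and "the series" means these compounds.

Measured so far:
- compound 1 `O=C(NCc1ccc(S(=O)(=O)N2CCCCC2)cc1)c1ccn2cncc2c1`: 1%
- compound 2 `Cc1cccc(S(=O)(=O)c2ccc(CNC(=O)c3cc4cnccc4[nH]3)cc2)c1`: 32%

In an ADME assay on microsomes from liver (Mus musculus) for metabolic stability, read by LC-MS, with a stated time of 30 min, tested at 1 uM (on this read-out higher numbers stand for a more stable compound and lower numbers for a less stable compound), compound 1 gives 1%, the lowest of the two numbers. Compound 2, the only comparator, gives 32% in this assay, a gap that lies beyond the usual scatter; the two compounds differ in several places at once, so no single step can be read from them.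

Compound 3 `O=C(NCc1ccc(S(=O)(=O)N2CCCCC2)cc1)c1ccc2nc[nH]c2c1` is not yet measured in this assay. It keeps the amide, the benzylic linker and the sulfonyl piperidine of compound 1 and changes only the group on the carbonyl carbon: a group of 9 heavy atoms (7 carbon, 2 nitrogen; one five-membered aromatic ring with 2 hetero atoms, one six-membered aromatic ring of carbon only) in place of a group of 9 heavy atoms (7 carbon, 2 nitrogen; one five-membered aromatic ring with 2 hetero atoms, one six-membered aromatic ring with 1 hetero atom), on a carbonyl carbon. The two compounds have the same atoms, joined differently.

Going by the values given here, no pair with a single change has been measured, so the size of the step in this assay is a guess. Compound 1 sits near the floor of the read-out, so a move downward can hardly be seen; a move upward of modest size is expected, with the step from compound 1 to compound 3 estimated at a number 9 percentage points higher from compound 1 to compound 3 (within the scatter). For compound 3 the expected value in this assay is 10%, within 1% to 35%.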

Compound 3, percent of the compound remaining: 16%
Estimate against measurement, compound 3: 6 percentage points below, within the range that was stated.
By their numbers in this assay, from the lowest: compound 1; then compound 3; then compound 2.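

In this assay, going by these compounds alone, exchanging the group on the carbonyl carbon for 1H-benzimidazol-6-yl gives a number 15 percentage points higher from compound 1 to compound 3 (beyond the scatter) and provides the first single-change reading. With the amide, the benzylic linker and the sulfonyl piperidine held constant and the atom count unchanged, the way these atoms are joined in this group is enough to shift the read-out measurably, so this position is not silent for stability in mouse microsomes. The entering group has 1 hydrogen-bond donor and 1 hydrogen-bond acceptor against 0 hydrogen-bond donors and 2 hydrogen-bond acceptors in the leaving group, but no measurement on these compounds explains the step.

On these data alone, a single pair cannot separate the contribution of the amide-linked group from any dependence on the rest of the molecule, so it remains open whether the step would carry over to a compound with a morpholine in place of the piperidine. Also open, as far as these compounds go, is how a methyl group on the benzimidazole nitrogen that bears the hydrogen, or a fluorine on its carbon ring, would read in this assay.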